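This account rests on a few compounds, and the source may have more. Where it says the series, first, only, none or still open, it means among the compounds named here.

Working notes on the series.

Compound 2 `O=C1NC(=O)C(Cc2ccc(Oc3ncc(C(F)(F)F)cc3Cl)cc2Cl)S1` carries the trifluoromethyl on the ring with one nitrogen and a chloro on the central aromatic ring. In a functional assay for agonist activity at Free fatty acid receptor 1 (Homo sapiens), read by FLIPR, in the presence of a further agent that is not named here (on this read-out higher numbers stand for an effect only at larger amounts of compound and lower numbers for an effect already at smaller amounts), compound 2 gives 26 nM. Compound 1 `O=C1NC(=O)C(Cc2ccc(Oc3ncc(Cl)cc3Cl)cc2)S1` lacks the chloro on the central ring and has chloro rather than trifluoromethyl on the nitrogen-containing ring; in this assay compound 1 gives 90 nM. Of the two numbers obtained so far, the number of compound 2 is the lower one, and the gap to compound 1 lies beyond the usual scatter. Among the compounds with values here, no single-change pair between measured compounds exists, so the contribution of either change on its own cannot be read from these two values.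

Compound 3 `O=C1NC(=O)C(Cc2ccc(Oc3ncc(Cl)cc3Cl)cc2Cl)S1` has not yet been measured. It arises from compound 2 by chloro in place of trifluoromethyl on an aromatic carbon. The difference between compound 1 and compound 3 is then only the chloro on the central ring. Because compound 1 gives 90 nM and compound 2 gives 26 nM, the number for compound 3 is expected to fall between the two, which means an expected step of a 1.9-fold higher number from compound 2 to compound 3 (0.28 log units; within the scatter) toward a larger number, roughly at the edge of the scatter. The estimate for compound 3 in this assay is 50 nM, with a range from 20 nM to 130 nM.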

Compound 3, half-maximal effective concentration: 63 nM
The estimate for compound 3 lay 1.3-fold (0.10 log units) below the measured number, within the range that was stated.
By their numbers in this assay, from the lowest: compound 2; then compounds 3 and 1 (each within the scatter of the next).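

In this assay, the position on the ring with one nitrogen, two atoms from the ring nitrogen and para to a large group, now has its first single-change reading: chloro in place of trifluoromethyl gives a 2.4-fold higher number from compound 2 to compound 3 (0.38 log units; beyond the scatter), a modest step but one that can be told from the scatter. Within the data shown here, on the other side, chloro in place of hydrogen on an aromatic carbon gives a 1.4-fold lower number from compound 1 to compound 3 (0.15 log units; within the scatter), so that this change on its own cannot be told from the scatter, and of the two single changes now readable, only the one at the trifluoromethyl position exceeds it. The measurements at hand offer nothing that would explain the size of either step.

The compounds shown leave open whether the step between trifluoromethyl and chloro keeps its size on the core of compound 1, where hydrogen stands in place of the second chloro. They also leave open how this position responds to groups outside this pair, such as a nitrile, a methoxy group or an amine, or to hydrogen there.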